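The compounds below may be only part of what the source reports. "The series", "measured", "known", "first", "only" and "open" are said of these compounds alone.

In an assay on LtK cells with ATP-sensitive inward rectifier potassium channel 11 (Homo sapiens) as the target (on this read-out lower numbers stand for an effect already at smaller amounts and higher numbers for an effect only at larger amounts of compound), compound 3 `O=C(Nc1c(C(O)(C(F)(F)F)C(F)(F)F)ccc2ccccc12)c1ccc(Br)cc1` gives 47 nM. Compound 1 `CC(C)=CC(=O)Nc1c(C(O)(C(F)(F)F)C(F)(F)F)ccc2ccccc12` gives 46 nM, and a 1.0-fold higher number from compound 1 to compound 3 (0.01 log units; within the scatter) lies within the scatter. Compound 2 `COCC(=O)Nc1c(C(O)(C(F)(F)F)C(F)(F)F)ccc2ccccc12` gives 213 nM, and a 4.5-fold lower number from compound 2 to compound 3 (0.66 log units; beyond the scatter) is clear. Compound 4 `O=C(Nc1c(C(O)(C(F)(F)F)C(F)(F)F)ccc2ccccc12)c1ccc(OC(F)(F)F)cc1` differs from compound 3 by trifluoromethoxy in place of bromo on an aromatic carbon. Within the data shown here, no measured step alters a group on this ring; the steps that involve the 4-bromophenyl, a 1.0-fold higher number from compound 1 to compound 3 (0.01 log units; within the scatter) and a 4.5-fold lower number from compound 2 to compound 3 (0.66 log units; beyond the scatter), replace the whole group and show that a sizeable aromatic group is not worse than a methoxymethyl. For a change at one spot of the ring, the expected step is a 1.3-fold higher number from compound 3 to compound 4 (0.11 log units; within the scatter), not beyond the scatter. Compound 4 is therefore estimated at 60 nM, within a range from 25 nM to 150 nM.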

Compound 4, half-maximal effective concentration: > 10000 nM
Compound 4: no number, only a limit (the forecaster's own chance of this, stated with the estimate: 3%); middle value at least 160-fold (2.22 log units) from the limit.
By their numbers in this assay, from the lowest: compounds 1 and 3 (each within the scatter of the next); then compound 2. At a limit, above all of these: compound 4.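

Compound 4 gives only a limit, not a number: the limit of > 10000 nM in this assay, at which 1 of the 4 values shown sits. On this ring a single swap of bromo for trifluoromethoxy matters far more than the whole-group swaps seen earlier, with an at least 210-fold higher number from compound 3 to compound 4 (2.32 log units; beyond the scatter). The 4-(trifluoromethoxy)phenyl group also falls behind 2-methylprop-1-en-1-yl, with an at least 210-fold higher number from compound 1 to compound 4 (2.33 log units; beyond the scatter), and behind methoxymethyl, with an at least 46-fold higher number from compound 2 to compound 4 (1.67 log units; beyond the scatter), so an aromatic group on the carbonyl does not by itself preserve the effect.

As far as these compounds go, whether chloro, methoxy or an amine in this place would stay close to compound 3 remains open. The compounds shown also cannot tell which feature of the swap is responsible.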